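Stereochemistry and a nitro-for-carbamoyl swap on a shared core

The source may hold more compounds than are shown below. What is called first, only, known or untested is meant among the compounds shown, and "the series" means these compounds.

Measured so far:
- compound 1 `COc1ccc(/C=C2\c3cc(OC)c(OC)c(OC)c3CC[C@@H]2O)cc1C(N)=O`: 550 nM
- compound 2 `COc1ccc(/C=C2\c3cc(OC)c(OC)c(OC)c3CC[C@@H]2O)cc1[N+](=O)[O-]`: 1590 nM
- compound 3 `COc1ccc(/C=C2\c3cc(OC)c(OC)c(OC)c3CC[C@H]2O)cc1C(N)=O`: 550 nM

All three compounds were tested in a functional assay on HT-29 cells (Homo sapiens) for inhibition, read by MTT assay; a lower number here means a stronger inhibitor, a higher number a weaker inhibitor. Compound 1 gives 550 nM, and compound 3, in this assay, gives 550 nM. The two share every atom and bond and differ only in how one centre is drawn: the two compounds have the same atoms and bonds and differ only in configuration as drawn: 1 of 2 stereo elements differ; a stereocentre at a saturated ring carbon is drawn S in compound 1 and R in compound 3. Their readings show no change at the digits printed from compound 1 to compound 3 (within the scatter), which fits with the fact that compounds 1 and 3 differ only in the configuration as drawn, so the two drawn configurations are not told apart by this measurement.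

The other change is a replacement of one small group by another on the aromatic ring: nitro in place of carbamoyl on an aromatic carbon. It brings a 2.9-fold higher number from compound 1 to compound 2 (0.46 log units; beyond the scatter), a weakening that lies beyond the usual scatter. Compound 2 gives 1590 nM in this assay.

Compound 4 `COc1ccc(/C=C2\c3cc(OC)c(OC)c(OC)c3CC[C@H]2O)cc1[N+](=O)[O-]` has not yet been measured. It stands to compound 3 exactly as compound 2 stands to compound 1: nitro in place of carbamoyl on an aromatic carbon. The place of the change is described in the same words for both pairs, so this is the same change made on the other drawn configuration. Because compound 1 and compound 3 showed no change at the digits printed from compound 1 to compound 3 (within the scatter), the swap is expected to behave as it did in a 2.9-fold higher number from compound 1 to compound 2 (0.46 log units; beyond the scatter). Compound 4 is therefore estimated at 1550 nM, between 750 nM and 3300 nM, an expected step of a 2.8-fold higher number from compound 3 to compound 4 (0.45 log units; beyond the scatter).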

Compound 4, half-maximal inhibitory concentration: > 10000 nM
Compound 4: a limit, no number; the forecaster's own chance of this, stated with the estimate: 2%; at least 6.4-fold (0.80 log units) between middle value and limit.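

Compound 4 gives > 10000 nM in this assay, which is a limit of the assay and not a number. Nitro in place of carbamoyl brings an at least 18-fold higher number from compound 3 to compound 4 (1.25 log units; beyond the scatter), so this swap does not carry over at one size from one drawn configuration to the other: the same change on two cores in this assay, a 2.9-fold higher number (0.46 log units; beyond the scatter) from compound 1 to compound 2 and an at least 18-fold higher number (1.25 log units; beyond the scatter) from compound 3 to compound 4, at least 6.2-fold (0.79 log units) apart, beyond the scatter of two such steps. The configuration left compound 1 and compound 3 level at the digits printed, yet it separates the nitro pair, with an at least 6.2-fold higher number from compound 2 to compound 4 (0.79 log units; beyond the scatter), and these two pairs show only that the outcome of the swap depends on the configuration, not the full size of the gap, its cause, or any rule for other cores: the fact that compounds 2 and 4 differ only in the configuration as drawn.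

On these data alone, it remains open whether other groups in the place of the carbamoyl, such as an amine, a carboxylic acid or a nitrile, would also give readings that depend on the configuration. As far as these compounds go, it is also open whether the same split would appear if the methoxy group on that ring gave way to a longer chain.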